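A few compounds are considered here, and "the series" means these few. Any claim that something is new, unique, unknown or untested is made for them only; others in the source may bear on it.

The account begins with compound 2, `C/C=C\c1nc(CC/C=C\C(=O)O[C@H]2C[C@@H]3CC(=O)O[C@@H](CCC)C[C@@H](OC)C/C(C)=C\[C@H](C2)O3)co1`, which in a functional assay on A549 cells (Homo sapiens) for antiproliferative activity, read by WST assay, with a stated time of 120 h (on this read-out higher numbers stand for weaker inhibition and lower numbers for stronger inhibition), gives 740 nM. Among the compounds with values here, of the three measured members, compound 2 stands at the highest number. Compound 1, `CCC[C@H]1C[C@@H](OC)C/C(C)=C\[C@@H]2C[C@@H](OC(=O)/C=C(/C)CCc3coc(/C=C\CNC(=O)OC)n3)C[C@H](CC(=O)O1)O2`, gives 6.3 nM in this assay, and compound 3, `CCC[C@H]1C[C@@H](OC)C/C(C)=C\[C@@H]2C[C@@H](OC(=O)/C(C)=C\CCc3coc(/C=C\CNC(=O)OC)n3)C[C@H](CC(=O)O1)O2`, gives 2.5 nM; both lie far below compound 2, and the gaps are well beyond the scatter of repeated measurements. Within the data shown here, compound 1 and compound 3 each differ from compound 2 in more than one place, so no single counted step connects them to it.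

Compound 4, `CCC[C@H]1C[C@@H](OC)C/C(C)=C\[C@@H]2C[C@@H](OC(=O)/C=C\CCc3coc(C=C(C)C)n3)C[C@H](CC(=O)O1)O2`, has not yet been measured. It differs from compound 2 in one place: 2-methylprop-1-en-1-yl in place of prop-1-en-1-yl on an aromatic carbon. Among the measured compounds shown here, no measured pair in the set isolates this change, so there is no direct precedent for its size or direction. A single added carbon on a chain that sits on an aromatic carbon is, in this reviewer's expectation, unlikely to move the number far, and the step from compound 2 to compound 4 is estimated at a 1.3-fold lower number from compound 2 to compound 4 (0.13 log units; within the scatter), which is not beyond the usual scatter. Compound 4 is therefore expected to give about 550 nM in this assay, with a range from 150 nM to 2000 nM.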

Compound 4, half-maximal inhibitory concentration: 3900 nM
Compound 4: the middle estimate sits 7.1-fold (0.85 log units) below what was measured; measured number above the stated range.
By their numbers in this assay, from the lowest: compound 3; then compound 1; then compound 2; then compound 4.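

The added carbon is not a silent change at this position: in this assay, putting 2-methylprop-1-en-1-yl in place of prop-1-en-1-yl gives a 5.3-fold higher number from compound 2 to compound 4 (0.72 log units; beyond the scatter) and so costs antiproliferative potency. Within the data shown here, this shows that the aromatic carbon next to the ring nitrogen and next to the ring oxygen is sensitive to a single added carbon in the group it carries, something the earlier compounds could not show, since none of them is joined to another by a single counted step. Nothing available accounts for the size or direction of this step.

The compounds shown leave open whether the loss belongs to the branching of the double-bonded chain or would also follow from other groups on this carbon, such as a saturated propyl chain, a longer chain or an amine. Among these compounds, they also leave open whether the same swap would have a step of similar size on a compound with a different ester side chain, as the single pair here gives only one reading of this change.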